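The compounds below may be only part of what the source reports. "The series", "measured", "known", "first", "only" and "open" are said of these compounds alone.

Measured so far in an ADME assay on microsomes from liver (Homo sapiens) for metabolic stability, using NADPH, with a stated time of 10 min; on this read-out lower numbers stand for a less stable compound and higher numbers for a more stable compound:
- compound 1 `NCCCCN(C[C@@H]1Cc2ncccc2CN1)[C@H]1CCCc2cccnc21`: 98%
- compound 2 `NC(=O)NC/C=C/CN(C[C@H]1Cc2ncccc2CN1)[C@H]1CCCc2cccnc21`: 93%

Both measured compounds share the same core and the same amine nitrogen carrying the side chain; they differ only in that side chain. On the numbers at hand, compound 2 is the lower of the two, with compound 1 the nearest neighbour, and the gap between them lies within the scatter, so nothing can be said about an order between the two.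

Compound 3 `c1cnc2c(c1)CN[C@@H](CN(CCCCNC1COC1)[C@H]1CCCc3cccnc31)C2` has not yet been measured in this assay. Compared with compound 2 the change is a group of 8 heavy atoms (6 carbon, 1 nitrogen, 1 oxygen; one four-membered non-aromatic ring with 1 hetero atom) in place of a group of 7 heavy atoms (4 carbon, 2 nitrogen, 1 oxygen; no ring), on a saturated chain carbon bound to an amine nitrogen.

Going by the values given here, no step between measured compounds is available to anchor the change. Both measured side chains give high remaining fractions in this assay, which suggests the core and the amine nitrogen substitution tolerate chain variation well. For compound 3 the step from compound 2 is expected to be small and, if anything, downward, with a number 5 percentage points lower from compound 2 to compound 3 (within the scatter) as the estimated shift, most likely staying within the scatter. The expected value for compound 3 in this assay is 88%, with a range from 70% to 99%.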

Compound 3, percent of the compound remaining: 97%
Estimate against measurement, compound 3: 9 percentage points below, and the stated range covers the measured number.
By their numbers in this assay, from the lowest: compounds 2, 3 and 1 (each within the scatter of the next).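

In this assay, putting a group of 8 heavy atoms with one four-membered non-aromatic ring with 1 hetero atom in place of a ring-free group of 7 heavy atoms, on a saturated chain carbon bound to an amine nitrogen, gives a number 4 percentage points higher from compound 2 to compound 3 (within the scatter). Going by these compounds alone, this is the first single-place comparison, and it shows that this position accepts two quite different groups, one with a ring and one without, with no difference that can be read in this assay. No measurement bears on why the two compounds cannot be told apart here.

Within the data shown here, the single step rests on one pair of compounds, so it does not show whether a carboxylic acid, a tertiary amine or a longer chain at this place would also leave the number within the scatter of compound 2. It also leaves open whether the same exchange would behave alike in a compound with a different core, and whether a longer incubation than the one stated for this assay would separate compound 2 from compound 3.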